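This account rests on a few compounds, and the source may have more. Where it says the series, first, only, none or still open, it means among the compounds named here.

Measured so far in a functional assay on HeLa cells (Homo sapiens) for antiproliferative activity, read by MTT assay, with a stated time of 72 h; on this read-out higher numbers stand for weaker inhibition and lower numbers for stronger inhibition:
- compound 1 `CC(C)=CC(=O)Nc1cccc(Oc2nc(Nc3cccc(C#N)c3)nc3c2CSCC3)c1` gives 29200 nM
- compound 2 `CC/C=C/C(=O)Nc1cccc(Oc2nc(Nc3ccc(OC)cc3)nc3c2CSCC3)c1` gives 27200 nM

Among the compounds with values here, compound 2 stands level with compound 1, the only other measured compound, as the two values lie within the scatter of each other.

Within the data shown here, compound 3 `COc1ccc(Nc2nc3c(c(Oc4cccc(NC(=O)C=C(C)C)c4)n2)CSCC3)cc1` has the same atoms as compound 2, joined differently, with 2-methylprop-1-en-1-yl in place of but-1-en-1-yl on a carbonyl carbon as the only change.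

Among the measured compounds shown here, no measured pair isolates this change. Compound 1 carries the same 2-methylprop-1-en-1-yl and gives 29200 nM in this assay while differing from compound 2 elsewhere as well. On that basis, the step of a 1.0-fold higher number from compound 2 to compound 3 (0.01 log units; within the scatter) is expected to stay within the scatter, with no direction expected.

Compound 3 is estimated at 28000 nM with an expected range from 13000 nM to 60000 nM.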

Compound 3, half-maximal inhibitory concentration: 19100 nM
For compound 3 the middle estimate is 1.5-fold (0.17 log units) above the measured one, within the range that was stated.
By their numbers in this assay, from the lowest: compounds 3, 2 and 1 (each within the scatter of the next).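

In this assay, within the data shown here, the first pair to isolate the chain on the carbonyl carbon gives a 1.4-fold lower number from compound 2 to compound 3 (0.15 log units; within the scatter), so 2-methylprop-1-en-1-yl and but-1-en-1-yl are not told apart at this position. Among these compounds, the first pair to isolate the group on a nitrogen on an aromatic ring gives a 1.5-fold lower number from compound 1 to compound 3 (0.18 log units; within the scatter), also within the scatter, so 4-methoxyphenyl and 3-cyanophenyl are not told apart there either. No supporting data bear on these results.

As far as these compounds go, whether a longer chain or a chain carrying an amine on the carbonyl carbon moves the number beyond the scatter remains open. Also open, from the compounds shown here alone, is the effect of a carboxylic acid in place of the nitrile or methoxy group on the phenyl ring.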